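The source may report more compounds than this note shows. Statements on the series, on what has been measured and on what is new or still open speak of the compounds shown alone.

Measured in a physicochemical assay for lipophilicity, at pH 7.4; on this read-out lower numbers stand for lower lipophilicity and higher numbers for higher lipophilicity:
- compound 1 `O=S(=O)(c1ccc2c(c1)C(O)CC(C1CCOCC1)O2)N1CCC(c2ccccc2)CC1`: 2.63
- compound 2 `CC(C)CN(c1ccc(F)cc1)S(=O)(=O)c1ccc2c(c1)C(O)CC(C1CCOCC1)O2`: 3.39
- compound 3 `CCc1ccc(N(CC(C)C)S(=O)(=O)c2ccc3c(c2)C(O)CC(C2CCN(C(=O)C4CCCC4)CC2)O3)cc1`: 5.04

Compound 2 stands second highest of the three. The nearest value belongs to compound 1, lower and beyond the scatter, and the furthest to compound 3, higher and also beyond the scatter.

Compound 4 `CC(C)CN(c1ccc(F)cc1F)S(=O)(=O)c1ccc2c(c1)C(O)CC(C1CCOCC1)O2` has not yet been measured in this assay. It departs from compound 2 in one place: fluoro in place of hydrogen on an aromatic carbon. This is fluoro in place of hydrogen on an aromatic carbon, ortho to a large group and meta to a fluoro group, the change from 4-fluorophenyl to 2,4-difluorophenyl.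

Among the measured compounds shown here, no measured pair shows this change alone, and the three values give no direct size for it. A small upward step in this assay is expected, most likely not beyond the scatter. The expected step is a number 0.11 log units higher from compound 2 to compound 4 (within the scatter). The estimate for compound 4 is 3.5, with an expected range of 3.2 to 3.8.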

Compound 4, distribution coefficient: 3.53
Compound 4: the middle estimate sits 0.03 log units below what was measured; the range from low to high includes it.
By their numbers in this assay, from the lowest: compound 1; then compounds 2 and 4 (each within the scatter of the next); then compound 3.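

Among the compounds shown here, compound 4 gives the first direct reading of fluoro in place of hydrogen on an aromatic carbon, ortho to a large group and meta to a fluoro group: in this assay the change from 4-fluorophenyl to 2,4-difluorophenyl gives a number 0.14 log units higher from compound 2 to compound 4 (within the scatter) on the shared core. For the compounds shown here, this position therefore takes the added fluoro with no step that stands clear of repeat scatter, and compound 2 and compound 4 read as one level. No measurement at hand bears on why the step has this size.

This single pair does not show whether a different group at this position, such as chloro, methoxy or an amine, would also stay level with compound 2. As far as these compounds go, whether the same fluoro change gives a like step in other members, such as compound 1 or compound 3, also remains open.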